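From Benzyl to Phenyl on One Nitrogen

The compounds below may be only part of what the source reports. "The series", "measured", "known", "first", "only" and "open" are said of these compounds alone.

In a functional assay on K562 cells (Homo sapiens) for inhibition, read by fluorescence, with a stated time of 72 h (a lower number here means a stronger inhibitor of growth, a higher number a weaker inhibitor of growth), compound 1 `COc1ccc(Nc2nc(N[C@H]3CC[C@H](N)CC3)nc3c2ncn3CCC(C)C)c(OC)c1` gives 5500 nM, compound 2 `COc1ccc(Cn2cnc3c(Nc4cccc(Cl)c4)nc(N[C@H]4CC[C@H](N)CC4)nc32)cc1` gives 2800 nM and compound 3 `CC(C)CCn1cnc2c(NCc3cccc(Cl)c3)nc(N[C@H]3CC[C@H](N)CC3)nc21` gives 3100 nM. Compound 3 thus lies within the usual scatter of both others. Compound 4 `CC(C)CCn1cnc2c(Nc3cccc(Cl)c3)nc(N[C@H]3CC[C@H](N)CC3)nc21` carries 3-chlorophenyl in place of 3-chlorobenzyl on a nitrogen on an aromatic ring, counted as 3-chlorophenyl in place of 3-chlorobenzyl on a nitrogen on an aromatic ring. Among the measured compounds shown here, the only measured step at this nitrogen, a 1.8-fold lower number from compound 1 to compound 3 (0.25 log units; within the scatter), stayed within the scatter. Compound 2 also carries 3-chlorophenyl there, with a different group elsewhere, and gives 2800 nM. No shift beyond the scatter is therefore expected, and the estimated step is a 1.0-fold lower number from compound 3 to compound 4 (0.01 log units; within the scatter). Compound 4 is expected near 3000 nM, within an estimated range of 1300 nM to 7000 nM.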

Compound 4, concentration for 50% growth inhibition: 1500 nM
Estimate against measurement, compound 4: 2.0-fold (0.30 log units) above, and the stated range covers the measured number.
By their numbers in this assay, from the lowest: compounds 4, 2, 3 and 1 (each within the scatter of the next, the first and the last beyond it).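

Among the compounds shown here, replacing 3-chlorobenzyl with 3-chlorophenyl on this nitrogen gives the first step at this position that lies beyond the scatter (a 2.1-fold lower number from compound 3 to compound 4 (0.32 log units; beyond the scatter)). Replacing 2,4-dimethoxyphenyl with 3-chlorophenyl there also goes beyond it (a 3.7-fold lower number from compound 1 to compound 4 (0.56 log units; beyond the scatter)), whereas the same replacement with 3-chlorobenzyl did not. Isobutyl in place of 4-methoxyphenyl on a saturated chain carbon bound to an aromatic nitrogen stays within the scatter (a 1.9-fold lower number from compound 2 to compound 4 (0.27 log units; within the scatter)). Going by these compounds, how a 2-phenylethyl group or a plain phenyl group would behave on this nitrogen remains open. Nothing shown gives a reason for these steps.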